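Adding a methoxy group to compound 1

This account rests on a few compounds, and the source may have more. Where it says the series, first, only, none or still open, it means among the compounds named here.

Among the measured compounds shown here, in a functional assay on A2780 cells (Homo sapiens) for antiproliferative activity, read by MTT assay, with a stated time of 48 h (a higher number here means a weaker inhibitor of growth, a lower number a stronger inhibitor of growth), compound 1 (`COC(=O)N1N=C(c2ccccc2)CC1c1cc(OC)c(OC)c(OC)c1`) gives 2770 nM, the lower of the two exact numbers measured so far. Compound 2 (`CCCOC(=O)N1N=C(c2ccccc2)CC1c1cc(OC)c(OC)c(OC)c1`), which differs only in a chain, gives 10800 nM. Compound 3 (`COc1cc(C2CC(c3ccccc3)=NN2C(=O)OCc2ccccc2)cc(OC)c1OC`), changed at the same place, gives > 10000 nM. That value is a limit of the assay and not a number.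

Compound 4 (`COC(=O)N1N=C(c2cccc(OC)c2)CC1c1cc(OC)c(OC)c(OC)c1`) keeps the chain of compound 1 and changes a different part of the molecule. It carries methoxy in place of hydrogen on an aromatic carbon, turning phenyl into 3-methoxyphenyl: methoxy in place of hydrogen on an aromatic carbon.

The measured steps are a 3.9-fold higher number from compound 1 to compound 2 (0.59 log units; beyond the scatter) and an at least 3.6-fold higher number from compound 1 to compound 3 (0.55 log units; beyond the scatter). Both go the same way and lie beyond the scatter, but both change the chain, so they bear on the new step only indirectly. They show that one local change can move the number in this small set, yet none tests a group on this aromatic ring. They therefore support no direction, and no step beyond the scatter is the central expectation, although a modest move either way remains possible.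

The expected outcome is a 1.1-fold lower number from compound 1 to compound 4 (0.04 log units; within the scatter). For compound 4 the estimated value is 2500 nM, with an expected range from 700 nM to 9000 nM.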

Compound 4, concentration for 50% growth inhibition: 2780 nM
For compound 4 the middle estimate is 1.1-fold (0.05 log units) below the measured one; the measured number falls inside the stated range.
By their numbers in this assay, from the lowest: compounds 1 and 4 (each within the scatter of the next); then compound 2.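

In this assay the new group gives a 1.0-fold higher number from compound 1 to compound 4 (0.00 log units; within the scatter) and so leaves the number in place, within the usual scatter of repeated measurements. Compound 2 and compound 3 changed only the chain, which makes compound 4 the first compound shown that tests a group on this aromatic ring, and here a methoxy group meta to a large group costs no measurable growth inhibition, whereas both readable chain changes moved the number beyond the scatter. Nothing shown here explains why this methoxy group makes no difference to the number.

A single methoxy group at a single place says little about other groups there, such as an amine, a carboxylic acid or a longer chain, or about a methoxy group elsewhere on this ring. The compounds shown also leave open whether this ring change would stay as silent on the chain of compound 2 or compound 3 as it does on the chain of compound 1.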